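A few compounds are considered here, and "the series" means these few. Any claim that something is new, unique, unknown or untested is made for them only; others in the source may bear on it.

Measured compounds:

Compound 1 `CCN(Cc1ccccc1)C(=O)C1CCN(S(=O)(=O)c2ccccc2OC)CC1` — in a functional assay on CHO cells for positive allosteric modulation of muscarinic acetylcholine receptor M5 (Homo sapiens), read by calcium flux (on this read-out higher numbers stand for larger maximal responses and lower numbers for smaller maximal responses), compound 1 gives "not determined" (no result reported).
Compound 2 `CCN(Cc1ccccc1)C(=O)C1CCN(S(=O)(=O)c2ccc3cn[nH]c3c2)CC1` — in this assay compound 2 gives 86%.
Compound 3 `CCN(Cc1ccccc1)C(=O)C1CCN(S(=O)(=O)c2ccc3nsnc3c2)CC1` — in this assay compound 3 gives 81%.

Going by the values given here, only two numbers are in hand. Compound 2 holds the higher of them, yet its nearest neighbour, compound 3, sits a number 5 percentage points lower from compound 2 to compound 3 (within the scatter), so the two cannot be told apart on this read-out. Compound 1 brings no number at all.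

Compound 4 `CCN(Cc1cccc(C(F)(F)F)c1)C(=O)C1CCN(S(=O)(=O)c2ccc3cn[nH]c3c2)CC1` differs from compound 2 in one place: trifluoromethyl in place of hydrogen on an aromatic carbon. Among the compounds with values here, the one measured step, from compound 2 to compound 3, lies on the sulfonyl side of the shared core and touches nothing on the benzyl ring; it therefore bears on this change only in showing that the largest response has so far moved little at all. Within the data shown here, no measured step concerns the benzyl ring itself.

With no relevant step beyond the scatter, compound 4 is expected to give a largest response close to that of compound 2, with the step of a number 4 percentage points lower from compound 2 to compound 4 (within the scatter) estimated to stay within the scatter. The estimate for compound 4 is 82%, with a range from 65% to 95%.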

Compound 4, largest response reached (reported as percent of maximum), in percent of the reference or control that the assay uses: 59%
For compound 4 the middle estimate is 23 percentage points above the measured one; the whole stated range lies above it.
By their numbers in this assay, from the lowest: compound 4; then compounds 3 and 2 (each within the scatter of the next).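

In this assay, trifluoromethyl in place of hydrogen on an aromatic carbon brings a number 27 percentage points lower from compound 2 to compound 4 (beyond the scatter), the first step among these compounds large enough to be read as a real change. The earlier measured step lay on the sulfonyl side and could not be told from scatter, so the benzyl ring is the only part of the shared core where the largest response has so far been seen to move, and it moved downward. No available evidence bears on what lies behind this drop.

Going by these compounds, with one group at one position, it remains open whether fluorine, chlorine, a methoxy group or a nitrile, placed meta to a large group on the same ring, would lower the response too. On these data alone, it is also open whether the 3-(trifluoromethyl)benzyl change would give a similar step on compound 3.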